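This account rests on a few compounds, and the source may have more. Where it says the series, first, only, none or still open, it means among the compounds named here.

Measured so far:
- compound 1 `Nc1ccc(C(=O)Nc2nnc(-c3ccc4c(c3)OCCO4)s2)cc1` — in a functional assay on HeLa cells (Homo sapiens) for antiproliferative activity, read by MTT assay, with a stated time of 48 h (a higher number here means that more compound is needed for the effect, a lower number that less compound is needed), compound 1 gives > 100 ug/mL, a limit of the assay rather than a number.
- compound 2 `O=C(Nc1nnc(-c2ccc3c(c2)OCCO3)s1)c1ccncc1` — in this assay compound 2 gives > 100 ug/mL, again only a limit.

Compound 2 thus stands at the limit, and both values shown sit there (the limit of > 100 ug/mL in this assay, at which 2 of the 2 values shown sit). Within the data shown here, the one measured step, a step that the two limits leave unreadable from compound 1 to compound 2, cannot be sized. Compound 3 `Cc1ccc(C(=O)Nc2nnc(-c3ccc4c(c3)OCCO4)s2)cn1` carries the change (6-methylpyridin-3-yl in place of pyridin-4-yl on a carbonyl carbon). With no readable step to lean on, no move beyond the scatter is expected, and the estimated step that the limit leaves unreadable from compound 2 to compound 3 is small. Compound 3 is expected near 120 ug/mL, between 40 ug/mL and 400 ug/mL.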

Compound 3, half-maximal effective concentration: > 100 ug/mL
Compound 3: no number, only a limit; the forecaster's own chance of this, stated with the estimate: 70%; the middle value is on the limit's open side.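

Among these compounds, compound 1, compound 2 and compound 3 each give only a limit of the assay, not a number, so no step among them can be read. Going by these compounds, whether any group on the carbonyl carbon gives a measurable value in this assay stays open.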